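A few compounds are considered here, and "the series" means these few. Any claim that something is new, unique, unknown or untested is made for them only; others in the source may bear on it.

Compound 2 `COc1cc(-c2nnc3n2NC(c2ccco2)C(C(=O)c2ccc(Cl)cc2)S3)cc(OC)c1OC` is one of three close relatives that share a core and differ in the aryl group attached to a carbonyl carbon. In a functional assay on HepG2 cells (Homo sapiens) for cytotoxicity, read by MTT assay, with a stated time of 48 h (a lower number here means a stronger inhibitor, a higher number a weaker inhibitor), compound 2 gives 78600 nM. Compound 1 `COc1cc(-c2nnc3n2NC(c2ccco2)C(C(=O)c2ccccc2C)S3)cc(OC)c1OC` gives 63000 nM and compound 3 `COc1cc(-c2nnc3n2NC(c2cccs2)C(C(=O)c2ccc(F)cc2)S3)cc(OC)c1OC` gives 54200 nM, so the number for compound 2 sits within the scatter of both. Compound 4 `COc1cc(-c2nnc3n2NC(c2ccco2)C(C(=O)c2ccc(F)c(F)c2)S3)cc(OC)c1OC` has not yet been measured. It differs from compound 2 by 3,4-difluorophenyl in place of 4-chlorophenyl on a carbonyl carbon. Going by the values given here, the only measured change at this position, a 1.2-fold higher number from compound 1 to compound 2 (0.10 log units; within the scatter), was small, so no step beyond the scatter is expected here either, and for compound 4 the expected step is a 1.2-fold lower number from compound 2 to compound 4 (0.08 log units; within the scatter). Compound 4 is therefore estimated at 65000 nM, with a likely range from 25000 nM to 160000 nM.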

Compound 4, half-maximal inhibitory concentration: 52400 nM
Compound 4: middle estimate off by 1.2-fold (0.09 log units), on the high side, within the range that was stated.
By their numbers in this assay, from the lowest: compounds 4, 3, 1 and 2 (each within the scatter of the next).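

In this assay, the three aryl groups on this carbonyl carbon now give a 1.5-fold lower number from compound 2 to compound 4 (0.18 log units; within the scatter) and a 1.2-fold lower number from compound 1 to compound 4 (0.08 log units; within the scatter). Replacing chlorine with two fluorines, or methyl with two fluorines, therefore leaves the number within the scatter, so 3,4-difluorophenyl, 4-chlorophenyl and 2-methylphenyl cannot be told apart here. Nothing measured explains this lack of separation.

All three groups are substituted phenyl rings. From the compounds shown here alone, how an amine, a carboxylic acid or a longer chain would behave on this carbonyl carbon remains open.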